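A few compounds are considered here, and "the series" means these few. Any claim that something is new, unique, unknown or untested is made for them only; others in the source may bear on it.

Measured so far in a functional assay for agonist activity at growth hormone secretagogue receptor type 1 (Homo sapiens), read by FLIPR; a higher number here means a larger maximal response, a lower number a smaller maximal response:

- compound 1 `COc1ccc(N2C[C@@H](C)N[C@@H](C)C2)cc1NS(=O)(=O)c1ccc(-c2cccs2)cc1`: 1
- compound 2 `COc1ccc(N2C[C@@H](C)N[C@@H](C)C2)cc1NS(=O)(=O)c1ccc(-c2cccs2)cc1Cl`: 0.9

Among the compounds with values here, compound 2 holds the lower of the two numbers, with compound 1 the nearer neighbour; the single step, a number 0.10 lower from compound 1 to compound 2 (within the scatter), stays within the scatter. Compound 3 `COc1ccc(N2C[C@@H](C)N[C@@H](C)C2)cc1NS(=O)(=O)c1ccc(-c2cccs2)cc1F` differs from compound 2 by fluoro in place of chloro on an aromatic carbon. Within the data shown here, the only step that bears on this place is a number 0.10 lower from compound 1 to compound 2 (within the scatter), where chloro in place of hydrogen left the intrinsic activity in this assay essentially unchanged; no larger move is therefore expected here. For compound 3 the estimate is 0.95, with a range of 0.8 to 1.05. This expectation amounts to a number 0.050 higher from compound 2 to compound 3 (within the scatter), nothing beyond the scatter.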

Compound 3, intrinsic activity: the largest response reached, as a fraction of the reference agonist's: 0.9
Compound 3: the middle estimate sits 0.050 above what was measured, within the range that was stated.
By their numbers in this assay, from the lowest: compounds 2, 3 and 1 (each within the scatter of the next).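

Fluoro in place of chloro gives no change at the digits printed from compound 2 to compound 3 (within the scatter) in this assay, so the two halogens are not told apart at this place, ortho to a large group and meta to a thiophen-2-yl group. Fluoro in place of hydrogen gives a number 0.10 lower from compound 1 to compound 3 (within the scatter) in this assay, so with fluoro as well as chloro, a halogen here does not separate from hydrogen. Nothing measured offers an explanation for this. As far as these compounds go, whether a methoxy, a nitrile or an amine at this place would hold the maximal response as these halogens do remains open.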